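This account rests on a few compounds, and the source may have more. Where it says the series, first, only, none or still open, it means among the compounds named here.

The compounds measured so far:
Compound 1 `Cn1cncc1C(OCc1ccc(C#N)cc1C#CC(C)(C)C)c1ccc(C#N)cc1`: 76.9 nM
Compound 2 `Cn1cncc1C(OCc1ccc(C#N)cc1-c1ccccc1)c1ccc(C#N)cc1`: 140 nM
Compound 3 `Cn1cncc1C(OCc1ccc(C#N)cc1/C=C/c1ccccn1)c1ccc(C#N)cc1`: 23.1 nM

All three share the same core and differ only in the group on one aromatic carbon. In a functional assay on NIH3T3 cells (Mus musculus) (on this read-out higher numbers stand for an effect only at larger amounts of compound and lower numbers for an effect already at smaller amounts), compound 3 gives the lowest of the three numbers: the step of a 3.3-fold lower number from compound 1 to compound 3 (0.52 log units; beyond the scatter) and the step of a 6.1-fold lower number from compound 2 to compound 3 (0.78 log units; beyond the scatter) both lie beyond the scatter, whereas the step of a 1.8-fold higher number from compound 1 to compound 2 (0.26 log units; within the scatter) does not.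

Compound 4 `Cn1cncc1C(OCc1ccc(C#N)cc1C#CC1(O)CCCCC1)c1ccc(C#N)cc1` has not yet been measured. Compared with compound 3, the change is 2-(1-hydroxycyclohexyl)ethynyl in place of 2-(pyridin-2-yl)ethenyl on an aromatic carbon. The entering group shares with the 3,3-dimethylbut-1-yn-1-yl group of compound 1 a triple bond outside aromatic rings, while the leaving group carries a double bond and an aromatic ring with a nitrogen. The step that bears most on this change is a 3.3-fold lower number from compound 1 to compound 3 (0.52 log units; beyond the scatter), a modest fall when a triple-bond group was replaced by the 2-(pyridin-2-yl)ethenyl group. Reversing that kind of exchange, a modest rise is therefore expected, a 2.6-fold higher number from compound 3 to compound 4 (0.41 log units; beyond the scatter), bringing compound 4 back toward the number of compound 1. For compound 4 the value in this assay is estimated at 60 nM, with a range from 20 nM to 180 nM.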

Compound 4, half-maximal effective concentration: 1.93 nM
The estimate for compound 4 lay 31-fold (1.49 log units) above the measured number; measured number below the stated range.
By their numbers in this assay, from the lowest: compound 4; then compound 3; then compounds 1 and 2 (each within the scatter of the next).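

In this assay, the triple bond does not settle the number on its own at this position, on an aromatic carbon ortho to a large group: compound 1 and compound 4 both carry one, yet 1-hydroxycyclohexyl in place of tert-butyl on the triple-bonded carbon gives the largest change among the groups that share this bond (a 40-fold lower number from compound 1 to compound 4 (1.60 log units; beyond the scatter)). The far end of the substituent therefore counts for much more than the first three compounds suggested, and 2-(1-hydroxycyclohexyl)ethynyl also leaves both aromatic-ring groups well behind (a 12-fold lower number from compound 3 to compound 4 (1.08 log units; beyond the scatter); a 73-fold lower number from compound 2 to compound 4 (1.86 log units; beyond the scatter)), making compound 4 the lowest of the four. The entering group brings a hydrogen-bond donor and a non-aromatic ring of carbon only, but no measurement available here explains the gain.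

The compounds shown do not separate the hydroxyl from the ring, a question that a plain cyclohexyl or a 2-hydroxypropan-2-yl group on the triple bond would address. Going by these compounds, how an amine in place of the hydroxyl, or a longer chain between the triple bond and the hydroxyl, would behave also stays open.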